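Thiophen-2-yl in Place of Phenyl on a Second Core

This account rests on a few compounds, and the source may have more. Where it says the series, first, only, none or still open, it means among the compounds named here.

Compound 1 `CSc1ncnc2c1c(-c1ccccc1)cn2[C@@H]1O[C@H](CO)[C@@H](O)[C@H]1O` is the starting point. In a functional assay on HepG2 cells (Homo sapiens) for antiproliferative activity, read by XTT assay, with a stated time of 72 h (on this read-out lower numbers stand for stronger inhibition and higher numbers for weaker inhibition), compound 1 gives > 20000 nM, which is a limit of the assay and not a number. Compound 3 `CSc1ncnc2c1c(-c1cccs1)cn2[C@@H]1O[C@H](CO)[C@@H](O)[C@H]1O` carries thiophen-2-yl in place of phenyl on an aromatic carbon. In this assay compound 3 gives > 20000 nM, again only a limit. The step that the two limits leave unreadable from compound 1 to compound 3 therefore cannot be sized. Compound 2 `Nc1nc(N)c2c(-c3ccccc3)cn([C@@H]3O[C@H](CO)[C@@H](O)[C@H]3O)c2n1` rests on another core; how the two cores differ is not broken down here. In this assay compound 2 gives > 20000 nM, which is a limit. Compound 4 `Nc1nc(N)c2c(-c3cccs3)cn([C@@H]3O[C@H](CO)[C@@H](O)[C@H]3O)c2n1` differs from compound 2 by thiophen-2-yl in place of phenyl on an aromatic carbon, the same change as before. Because (the limit of > 20000 nM in this assay, at which 3 of the 3 values shown sit), none of the shown compounds gives a readable number. The step is expected to be a step that the limit leaves unreadable from compound 2 to compound 4, resting on that shared limit. Compound 4 is expected to give 30000 nM in this assay, most likely as another limit.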

Compound 4, half-maximal inhibitory concentration: > 20000 nM
Compound 4 was reported as a limit; the forecaster's own chance of this, stated with the estimate: 85%; the middle value does not contradict the limit.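

No step can be read from compound 2 to compound 4, since both values are limits and not numbers: the limit of > 20000 nM in this assay, at which 4 of the 4 values shown sit. Going by these compounds, how strongly any of the four compounds inhibits, and whether thiophen-2-yl and phenyl differ on either core, stays open.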